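The source may report more compounds than this note shows. Statements on the series, on what has been measured and on what is new or still open speak of the compounds shown alone.

Measured compounds in a functional assay on cells (Lymphocyte, Homo sapiens); on this read-out lower numbers stand for stronger inhibition and higher numbers for weaker inhibition:

Compound 1, `Nc1nc(N2CCN(C(=O)OCc3ccccc3)CC2)c2nc(-c3ccc(F)cc3)sc2n1`, gives 4900 nM.
Compound 2, `Nc1nc(N2CCN(C(=O)COc3ccccc3)CC2)c2nc(-c3ccc(F)cc3)sc2n1`, gives 90 nM.
Compound 3, `Nc1nc(N2CCN(C(=O)COc3ccc(F)cc3)CC2)c2nc(-c3ccc(F)cc3)sc2n1`, gives 70 nM.

Compound 3 has the lowest number of the three, but its nearest neighbour is compound 2: the step of a 1.3-fold lower number from compound 2 to compound 3 (0.11 log units; within the scatter) lies within the scatter, so the two cannot be told apart. Compound 1 is far away, as the step of a 70-fold lower number from compound 1 to compound 3 (1.85 log units; beyond the scatter) shows, and the step of a 54-fold lower number from compound 1 to compound 2 (1.74 log units; beyond the scatter) tells the same story: exchanging the group on the carbonyl carbon matters a great deal, while the fluoro added in compound 3 did not.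

Compound 4, `Nc1nc(N2CCN(C(=O)COc3ccc(Br)cc3)CC2)c2nc(-c3ccc(F)cc3)sc2n1`, differs from compound 3 in one place: bromo in place of fluoro on an aromatic carbon. Within the data shown here, no measured pair shows bromo against fluoro, so the only step that bears on this change is a 1.3-fold lower number from compound 2 to compound 3 (0.11 log units; within the scatter), which changed the same aromatic carbon and stayed within the scatter. A halogen of a different size at that position has no comparison here, and the outcome is therefore uncertain, but nothing measured points toward a step beyond the scatter in either direction.

Compound 4 is expected to give about 70 nM, with a range from 25 nM to 200 nM. This estimate corresponds to a step of no change at the digits printed from compound 3 to compound 4 (within the scatter).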

Compound 4, half-maximal inhibitory concentration: 380 nM
For compound 4 the middle estimate is 5.4-fold (0.73 log units) below the measured one, outside the stated range (above it).
By their numbers in this assay, from the lowest: compounds 3 and 2 (each within the scatter of the next); then compound 4; then compound 1.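

In this assay, this aromatic carbon turns out to be sensitive to which halogen it carries: a 5.4-fold higher number from compound 3 to compound 4 (0.73 log units; beyond the scatter) is beyond the scatter, so the lack of any clear effect seen earlier applied to fluoro in place of hydrogen, not to every group placed there. Bromo also separates from hydrogen, with a 4.2-fold higher number from compound 2 to compound 4 (0.63 log units; beyond the scatter), which means that this position is not indifferent to substitution, even though the (4-bromophenoxy)methyl group still compares well with benzyloxy on the carbonyl carbon, as a 13-fold lower number from compound 1 to compound 4 (1.11 log units; beyond the scatter) shows. Nothing in the available data explains why bromo and fluoro differ here.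

Chloro, methyl or methoxy on this same carbon would help show whether the higher number is peculiar to bromo or also appears with other groups. The compounds shown also leave open how an amine or a carboxylic acid would behave there, and whether bromo would give the same result at another carbon of this six-membered ring.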